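Swapping the Aryl Amine Substituent in Compound 3

The compounds below may be only part of what the source reports. "The series", "measured", "known", "first", "only" and "open" are said of these compounds alone.

The three measured compounds share one core. Compound 1 `O=C(CSc1nc(Nc2ccccc2)c2ccccc2n1)Nc1cccc([N+](=O)[O-])c1` and compound 2 `O=C(CSc1nc(Nc2ccccc2)c2ccccc2n1)Nc1ccc(F)c(Cl)c1` differ only on an amide-type nitrogen. In a functional assay on MDA-MB-231 cells (Homo sapiens) for inhibition, read by MTT assay, with a stated time of 72 h (a higher number here means a weaker inhibitor, a lower number a stronger inhibitor), compound 1 gives 33000 nM, and compound 2 gives 21600 nM. The step of a 1.5-fold lower number from compound 1 to compound 2 (0.18 log units; within the scatter), 3-chloro-4-fluorophenyl in place of 3-nitrophenyl on an amide-type nitrogen, left the read-out essentially where it was.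

Compound 3 `C=CC(=O)Nc1cccc(NC(=O)CSc2nc(Nc3cccc([N+](=O)[O-])c3)c3ccccc3n2)c1` carries the 3-nitrophenyl on a nitrogen on an aromatic ring. For compound 3 the assay reports only a limit, > 50000 nM. Compound 3 thus stands at the limit of > 50000 nM in this assay, at which 1 of the 3 values shown sits, not at a number.

Compound 4 `C=CC(=O)Nc1cccc(NC(=O)CSc2nc(Nc3ccc(F)c(Cl)c3)c3ccccc3n2)c1` is the unmeasured partner: 3-chloro-4-fluorophenyl in place of 3-nitrophenyl on a nitrogen on an aromatic ring. This is the same exchange of groups that the measured step of a 1.5-fold lower number from compound 1 to compound 2 (0.18 log units; within the scatter) covered, here on a nitrogen on an aromatic ring rather than on an amide-type nitrogen, and that step lay within the scatter. Within the data shown here, no measured step distinguishes the two positions on this core, so a similarly small shift, in no firm direction, is expected in this assay. The estimated step is an at least 1.1-fold lower number from compound 3 to compound 4 (0.04 log units; that floor lies within the scatter). Compound 4 is expected to give 45000 nM, within a range from 20000 nM to 100000 nM, with a real chance that this assay once more reports only a limit.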

Compound 4, half-maximal inhibitory concentration: 10600 nM
The estimate for compound 4 lay 4.2-fold (0.63 log units) above the measured number; the whole stated range lies above it.
By their numbers in this assay, from the lowest: compound 4; then compounds 2 and 1 (each within the scatter of the next). At a limit, above all of these: compound 3.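

On a nitrogen on an aromatic ring, the exchange of 3-nitrophenyl for 3-chloro-4-fluorophenyl is not neutral in this assay: it gives an at least 4.7-fold lower number from compound 3 to compound 4 (0.67 log units; beyond the scatter), a step that can be read only as a floor. That floor rests on compound 3, which gives > 50000 nM, a limit of the assay and not a number, and it is the only such limit among the compounds shown: the limit of > 50000 nM in this assay, at which 1 of the 4 values shown sits. The earlier pair had suggested that this exchange of groups changes little, but the result shows that its size is not the same on the two cores: the same change on two cores in this assay, a 1.5-fold lower number (0.18 log units; within the scatter) from compound 1 to compound 2 and an at least 4.7-fold lower number (0.67 log units; beyond the scatter) from compound 3 to compound 4, at least 3.0-fold (0.48 log units) apart, beyond the scatter of two such steps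

The compounds shown leave open which part of the 3-chloro-4-fluorophenyl group goes with the lower number, as a phenyl carrying chlorine alone, fluorine alone or a methoxy group at this place could read either close to compound 4 or close to compound 3. Going by these compounds, the two cores also differ in more than one place, so it remains open which of those differences makes the exchange count on the core of compound 3 and not on the core of compound 1.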